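This account rests on a few compounds, and the source may have more. Where it says the series, first, only, none or still open, it means among the compounds named here.

Of the compounds shown here, three have been tested in an ADME assay on MDBK cells (Bos taurus) for cytotoxicity, read by MTT assay, with a stated time of 96 h; on this read-out lower numbers stand for higher toxicity in this test and higher numbers for lower toxicity in this test. Compound 1, `Clc1cccc(/N=N/N2CCCC2)c1`, gives > 100000 nM, which is a limit and not a number. Compound 2, `Clc1cccc(/N=N/N2CCCCC2)c1`, gives > 100000 nM, again a limit. Compound 3, `c1ccc(/N=N/N2CCN(c3ncccn3)CC2)cc1`, gives > 100000 nM, also a limit. Compound 2 therefore has no exact value of its own and stands with the others at the limit of > 100000 nM in this assay, at which 3 of the 3 values shown sit.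

Compound 4, `c1ccc(/N=N/N2CCCCC2)cc1`, has not yet been measured. It differs from compound 2 by hydrogen in place of chloro on an aromatic carbon. Within the data shown here, no measured pair shows this change, so the expectation rests only on the three limits. Compound 2 serves as the reference with > 100000 nM. The estimated step, a number no higher from compound 2 to compound 4 (the limit leaves the size open), is expected to be none beyond the scatter, and this assay may again report only a limit. For compound 4 the expected value is estimated at 100000 nM, within an expected range from 40000 nM to 200000 nM.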

Compound 4, half-maximal cytotoxic concentration: > 100000 nM
Compound 4 gave a limit, no number; the forecaster's own chance of this, stated with the estimate: 75%; the middle value lies on the limit itself.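

No step can be read from compound 2 to compound 4, as both give only a limit in this assay. The compounds shown leave open what effect hydrogen in place of chloro on an aromatic carbon has on a measured value, with every value still a limit: the limit of > 100000 nM in this assay, at which 4 of the 4 values shown sit.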